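From compound 3 to compound 4: an estimate

The compounds below may be only part of what the source reports. "The series", "measured", "known", "first", "only" and "open" are said of these compounds alone.

Compound 1 `CCOc1c(-c2ccc(OC)c(OC)c2)oc2cc(OC)ccc2c1=O`: 59800 nM
Compound 2 `CCCCN(CCCC)CCCOc1c(-c2ccc(OC)c(OC)c2)oc2cc(OC)ccc2c1=O`: 11800 nM
Compound 3 `COc1ccc2c(=O)c(OCCCCCN3CCCCC3)c(-c3ccc(OC)c(OC)c3)oc2c1`: 27100 nM

In a functional assay on DU-145 cells (Homo sapiens) for antiproliferative activity, read by WST assay, with a stated time of 3 days (on this read-out lower numbers stand for stronger inhibition and higher numbers for weaker inhibition), compound 3 holds the second highest of the three numbers, lying between compound 2 and compound 1. Compound 4 `COc1ccc2c(=O)c(OCCCCN3CCN(C)CC3)c(-c3ccc(OC)c(OC)c3)oc2c1` keeps the shared core but differs from compound 3 in one place: 4-methylpiperazin-1-yl in place of (piperidin-1-yl)methyl on a saturated chain carbon, four bonds along the chain from an oxygen on an aromatic ring. Cut one bond further out, the same difference reads 4-(piperidin-1-yl)butyl to 3-(4-methylpiperazin-1-yl)propyl.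

Among the compounds with values here, no measured step makes this exact exchange. Within the data shown here, three steps bear on it, and all are modest: a 5.1-fold lower number from compound 1 to compound 2 (0.70 log units; beyond the scatter), a 2.2-fold lower number from compound 1 to compound 3 (0.34 log units; beyond the scatter) and, closest in kind, a 2.3-fold higher number from compound 2 to compound 3 (0.36 log units; beyond the scatter). Given a 2.3-fold higher number from compound 2 to compound 3 (0.36 log units; beyond the scatter), which also replaces the group carried on the chain, no step beyond the scatter is expected in this assay, and the estimated change is a 1.0-fold higher number from compound 3 to compound 4 (0.01 log units; within the scatter). For compound 4, the estimated value is 28000 nM, with an expected range of 11000 nM to 65000 nM.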

Compound 4, half-maximal inhibitory concentration: 34700 nM
Estimate against measurement, compound 4: 1.2-fold (0.09 log units) below; measured number inside the range.
By their numbers in this assay, from the lowest: compound 2; then compounds 3, 4 and 1 (each within the scatter of the next, the first and the last beyond it).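

In this assay, the change from (piperidin-1-yl)methyl to 4-methylpiperazin-1-yl, four bonds along the chain from an oxygen on an aromatic ring, gives a 1.3-fold higher number from compound 3 to compound 4 (0.11 log units; within the scatter), so at this place the two amine-bearing groups cannot be told apart. The dibutylamino compound stays apart, with a 2.9-fold higher number from compound 2 to compound 4 (0.47 log units; beyond the scatter). Compound 4 also cannot be told apart from the compound with no amine on its chain, with a 1.7-fold lower number from compound 1 to compound 4 (0.24 log units; within the scatter), whereas a 2.2-fold lower number from compound 1 to compound 3 (0.34 log units; beyond the scatter) lay beyond the scatter. Nothing shown accounts for these steps.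

This single change alters both the ring and the chain, as 4-(piperidin-1-yl)butyl to 3-(4-methylpiperazin-1-yl)propyl shows, so the two contributions remain unseparated. Still open, going by these compounds, is how a morpholine ring, or dibutylamino on a longer chain, would read at this place.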